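Propyl for Ethyl on the Chloro Analogue

This account rests on a few compounds, and the source may have more. Where it says the series, first, only, none or still open, it means among the compounds named here.

Compound 1 `CCN1CC[C@@]2(OC)OC(N)=C(C#N)[C@@H](c3ccc(Br)cc3)[C@@H]2C1` gives 13200 nM in a functional assay on trachea (Cavia porcellus); a higher number here means a weaker inhibitor, a lower number a stronger inhibitor. Compound 2 `CCCN1CC[C@@]2(OC)OC(N)=C(C#N)[C@@H](c3ccc(Br)cc3)[C@@H]2C1` differs from it by methyl in place of hydrogen on a saturated chain carbon, two bonds along the chain from an amine nitrogen in a ring, and in this assay compound 2 gives 19400 nM, the step being a 1.5-fold higher number from compound 1 to compound 2 (0.17 log units; within the scatter). Compound 3 `CCN1CC[C@@]2(OC)OC(N)=C(C#N)[C@@H](c3ccc(Cl)cc3)[C@@H]2C1` differs from compound 1 by chloro in place of bromo on an aromatic carbon; in this assay compound 3 gives 14900 nM, a step of a 1.1-fold higher number from compound 1 to compound 3 (0.05 log units; within the scatter). Compound 4 `CCCN1CC[C@@]2(OC)OC(N)=C(C#N)[C@@H](c3ccc(Cl)cc3)[C@@H]2C1` has not been measured; it differs from compound 3 by methyl in place of hydrogen on a saturated chain carbon, two bonds along the chain from an amine nitrogen in a ring, the same change that separates compound 1 from compound 2, at a place described in identical words. The expected step is a 1.4-fold higher number from compound 3 to compound 4 (0.15 log units; within the scatter), resting on the earlier change having given a 1.5-fold higher number from compound 1 to compound 2 (0.17 log units; within the scatter) and on the cores differing only at the aromatic halogen. Compound 4 is therefore estimated at 21000 nM, with a range from 10000 nM to 45000 nM.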

Compound 4, half-maximal inhibitory concentration: 30300 nM
Estimate against measurement, compound 4: 1.4-fold (0.16 log units) below; measured number inside the range.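

In this assay, ethyl to propyl on the chloro core gave a 2.0-fold higher number from compound 3 to compound 4 (0.31 log units; beyond the scatter), and this step cannot be told apart from its counterpart on the bromo core: the same change on two cores in this assay, a 1.5-fold higher number (0.17 log units; within the scatter) from compound 1 to compound 2 and a 2.0-fold higher number (0.31 log units; beyond the scatter) from compound 3 to compound 4, 1.4-fold (0.14 log units) apart, within the scatter of two such steps. Chloro in place of bromo on the propyl core gave a 1.6-fold higher number from compound 2 to compound 4 (0.19 log units; within the scatter), and that swap likewise behaved alike on both cores: the same change on two cores in this assay, a 1.1-fold higher number (0.05 log units; within the scatter) from compound 1 to compound 3 and a 1.6-fold higher number (0.19 log units; within the scatter) from compound 2 to compound 4, 1.4-fold (0.14 log units) apart, within the scatter of two such steps. This shows agreement between two cores that differ in one place only; it does not show that the change would carry to any other core in the series, and it gives no reason for the size of the step.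

The compounds shown leave open whether a longer chain on the amine nitrogen in the ring would continue in the same direction. They also leave open whether the change would behave alike with fluoro on the aromatic carbon.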